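Fluoro in place of hydrogen on the chain of compound 1

The compounds below may be only part of what the source reports. "The series", "measured", "known", "first", "only" and "open" are said of these compounds alone.

Compound 1 `COc1cc(C(c2ccc(O)c(OC)c2)[C@H](C)C(C)C)ccc1O` stands lowest of the two numbers shown in a functional assay on HL-60 cells (Homo sapiens) for cytotoxicity, read by WST assay, with a stated time of 48 h; on this read-out lower numbers stand for stronger inhibition and higher numbers for weaker inhibition: compound 1 gives 17000 nM. Compound 2 `COC[C@@H](C(C)C)C(c1ccc(O)c(OC)c1)c1ccc(O)c(OC)c1` gives 54000 nM in this assay, so that a 3.2-fold higher number from compound 1 to compound 2 (0.50 log units; beyond the scatter). Compound 3 `COc1cc(C(c2ccc(O)c(OC)c2)[C@H](C)[C@@H](C)CO)ccc1O` reaches only a limit of this assay, > 100000 nM. From that limit it follows that an at least 5.8-fold higher number from compound 1 to compound 3 (0.76 log units; beyond the scatter), while an at least 1.8-fold higher number from compound 2 to compound 3 (0.26 log units; that floor lies within the scatter).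

Compound 4 `COc1cc(C(c2ccc(O)c(OC)c2)[C@H](C)[C@H](C)CF)ccc1O` has not yet been measured in this assay. Relative to compound 1 it carries fluoro in place of hydrogen on a saturated chain carbon, four bonds along the chain from two aromatic carbons. Going by the values given here, the step that bears most on it is the one from compound 1 to compound 3, where the same saturated chain carbon carries hydroxy instead, and that step was at least modest and upward. The step to compound 2 touched a different part of the chain and was smaller. A step upward beyond the scatter is therefore expected, though probably not as large as the one seen with hydroxy. Compound 4 is estimated to give 40000 nM, within 15000 nM to 100000 nM, which would mean a 2.4-fold higher number from compound 1 to compound 4 (0.37 log units; beyond the scatter).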

Compound 4, half-maximal inhibitory concentration: 56000 nM
Estimate against measurement, compound 4: 1.4-fold (0.15 log units) below, and the stated range covers the measured number.
By their numbers in this assay, from the lowest: compound 1; then compounds 2 and 4 (each within the scatter of the next). At a limit, above all of these: compound 3.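

In this assay, fluoro on a saturated chain carbon, four bonds along the chain from two aromatic carbons, also moves the number upward, a 3.3-fold higher number from compound 1 to compound 4 (0.52 log units; beyond the scatter), so the upward step at this position is no longer seen with hydroxy alone. The result with fluoro also stands level with the 1-(methoxymethyl)-2-methylpropyl chain, a 1.0-fold higher number from compound 2 to compound 4 (0.02 log units; within the scatter). Compound 3 gives only a limit of the assay, and the step read against it, an at least 1.7-fold lower number from compound 3 to compound 4 (0.25 log units; that floor lies within the scatter), does not separate fluoro from hydroxy.

From the compounds shown here alone, whether hydroxy and fluoro truly differ at this position stays open, with compound 3 at a limit: the limit of > 100000 nM in this assay, at which 1 of the 4 values shown sits. Also open, going by these compounds, is how an amine, a carboxylic acid or a longer chain at this carbon would read.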